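Aryl in place of isobutyl on the amide nitrogen

A few compounds are considered here, and "the series" means these few. Any claim that something is new, unique, unknown or untested is made for them only; others in the source may bear on it.

In a functional assay on QGY7701 cells (Homo sapiens) for cytotoxicity, read by MTT assay, with a stated time of 24 h (on this read-out higher numbers stand for weaker inhibition and lower numbers for stronger inhibition), compound 3 `C=CC1=C(C(=O)NCC(C)C)C(c2ccc(F)cc2)OC1` gives only a limit, > 100000 nM. Compound 1 `C=CC1=C(C(=O)NCc2ccc(C)cc2)C(c2ccc(F)cc2)OC1` gives 62100 nM and compound 2 `C=CC1=C(C(=O)Nc2ccccc2OC)C(c2ccc(F)cc2)OC1` gives 52800 nM. Compound 4 `C=CC1=C(C(=O)Nc2ccc(C)cc2)C(c2ccc(F)cc2)OC1` differs from compound 3 by 4-methylphenyl in place of isobutyl on an amide-type nitrogen. The step of an at least 1.8-fold higher number from compound 2 to compound 3 (0.27 log units; that floor lies within the scatter) and the step of an at least 1.6-fold higher number from compound 1 to compound 3 (0.20 log units; that floor lies within the scatter) both run toward the limit; the change to compound 4 runs the other way, replacing isobutyl with an aromatic ring of the kind compound 2 also carries on its amide nitrogen. A lower number in this assay is therefore expected for compound 4, as a step of an at least 1.8-fold lower number from compound 3 to compound 4 (0.25 log units; that floor lies within the scatter), though the floors of the measured steps lie within the scatter. Compound 4 is estimated at 55000 nM, within a range of 25000 nM to 110000 nM.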

Compound 4, half-maximal inhibitory concentration: 59200 nM
The estimate for compound 4 lay 1.1-fold (0.03 log units) below the measured number; low and high end bracket the measured number.
By their numbers in this assay, from the lowest: compounds 2, 4 and 1 (each within the scatter of the next). At a limit, above all of these: compound 3.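

In this assay, on these data alone, 4-methylphenyl in place of isobutyl on the amide-type nitrogen gives an at least 1.6-fold lower number from compound 3 to compound 4 (0.22 log units; that floor lies within the scatter); compound 3 is only a limit, so the full size of this step stays unknown. Against the other two ring-bearing groups, the new group gives a 1.1-fold higher number from compound 2 to compound 4 (0.05 log units; within the scatter) and a 1.0-fold lower number from compound 1 to compound 4 (0.02 log units; within the scatter). A methoxy group on the ring in place of a methyl group, or a saturated carbon between nitrogen and ring, thus shows no change beyond the scatter here.

The compounds shown leave open how a cyclohexyl group, with a ring that is not aromatic, would read at this nitrogen. They also leave open whether a pyridine ring or a carboxylic acid on the ring would move the number.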